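Replacing piperidin-1-yl with (diethylamino)methyl on the side chain

The source may report more compounds than this note shows. Statements on the series, on what has been measured and on what is new or still open speak of the compounds shown alone.

Values in an ADME assay on HEK293 cells (Homo sapiens) for cytotoxicity, read by MTT assay, with a stated time of 48 h (a lower number here means a stronger inhibitor, a higher number a weaker inhibitor), are as follows.
Compound 1 `Cn1c(N)c(-c2nc3ccccc3[nH]2)c2nc(C#N)c(C#N)nc21` gives > 50000 nM as a limit
Compound 2 `N#Cc1nc2c(-c3nc4ccccc4[nH]3)c(N)n(CCO)c2nc1C#N` gives > 50000 nM as a limit
Compound 3 `N#Cc1nc2c(-c3nc4ccccc4[nH]3)c(N)n(CCCN3CCCCC3)c2nc1C#N` gives 6720 nM as a number

Compound 3 is the only one of the three with a number in this assay and the other two stand at a limit (the limit of > 50000 nM in this assay, at which 2 of the 3 values shown sit). Compound 4 `CCN(CC)CCCCn1c(N)c(-c2nc3ccccc3[nH]2)c2nc(C#N)c(C#N)nc21` differs from compound 3 by this change: (diethylamino)methyl in place of piperidin-1-yl on a saturated chain carbon, three bonds along the chain from an aromatic nitrogen with (diethylamino)methyl in place of piperidin-1-yl on a saturated chain carbon, three bonds along the chain from an aromatic nitrogen.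

Two measured steps lead to the chain of compound 3 and both lie beyond the scatter: an at least 7.4-fold lower number from compound 1 to compound 3 (0.87 log units; beyond the scatter) and an at least 7.4-fold lower number from compound 2 to compound 3 (0.87 log units; beyond the scatter) are each at least modest. The remaining one, a step that the two limits leave unreadable from compound 1 to compound 2, gives no size. None of these steps exchanges one end group of this kind for another. Compound 4 is therefore judged from compound 3 alone (6720 nM) and no change beyond the scatter is expected. The expected change is a 1.3-fold lower number from compound 3 to compound 4 (0.13 log units; within the scatter) in this assay. For compound 4 the half-maximal inhibitory concentration is estimated at 5000 nM with an expected range from 1800 nM to 15000 nM.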

Compound 4, half-maximal inhibitory concentration: 5370 nM
Compound 4: the middle estimate sits 1.1-fold (0.03 log units) below what was measured; the measured number falls inside the stated range.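

In this assay, (diethylamino)methyl in place of piperidin-1-yl gives a 1.3-fold lower number from compound 3 to compound 4 (0.10 log units; within the scatter), so at this place on the chain the ring is not needed for the number to stay where compound 3 put it. The lower number is also not confined to piperidin-1-yl, since the open-chain 4-(diethylamino)butyl group of compound 4 gives an at least 9.3-fold lower number from compound 2 to compound 4 (0.96 log units; beyond the scatter) and an at least 9.3-fold lower number from compound 1 to compound 4 (0.96 log units; beyond the scatter). The size of these last two steps is bounded from one side only, as compound 1 and compound 2 each stand at a limit and not at a number: the limit of > 50000 nM in this assay, at which 2 of the 4 values shown sit.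

Going by these compounds, what a morpholine or a carboxylic acid would do as the end group of the chain stays open. So does the effect of a longer chain carrying piperidin-1-yl.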